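Amide aryl swap on the shared core: compound 3

A few compounds are considered here, and "the series" means these few. Any claim that something is new, unique, unknown or untested is made for them only; others in the source may bear on it.

Measured so far in a functional assay on HCC1937 cells (Homo sapiens) for antiproliferative activity, read by CCK-8 assay, with a stated time of 72 h; on this read-out lower numbers stand for stronger inhibition and higher numbers for weaker inhibition:
- compound 1, `O=C(Nc1cccc(-c2oc3cc(-c4ccc(F)cc4)ccc3c(=O)c2O)c1)c1ccc(Cl)cc1`: 4030 nM
- compound 2, `O=C(Nc1cccc(-c2oc3cc(-c4ccc(F)cc4)ccc3c(=O)c2O)c1)c1cccc(F)c1`: 6590 nM

For the measured compounds named here, compound 2 holds the higher of the two numbers in this assay, but its distance to compound 1 is small: the only single-point step available, a 1.6-fold higher number from compound 1 to compound 2 (0.21 log units; within the scatter), lies within the scatter, so the two compounds cannot be ranked against each other.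

Compound 3, `O=C(Nc1cccc(-c2oc3cc(-c4ccc(F)cc4)ccc3c(=O)c2O)c1)c1ccc(Cl)nc1`, is the next compound in the series and is not yet measured. It differs from compound 2 in one place: 6-chloropyridin-3-yl in place of 3-fluorophenyl on a carbonyl carbon

Going by the values given here, the one measured step bears on this change only in part. It covers the exchange of a halogen-bearing phenyl for another halogen-bearing phenyl on the same carbonyl carbon and produced no movement beyond the scatter. Among the compounds with values here, compound 3 brings back a chlorine, as in compound 1, while adding a ring nitrogen for which the series holds no precedent. On the evidence in hand the expected step of a 1.3-fold lower number from compound 2 to compound 3 (0.12 log units; within the scatter) is therefore small, at most a drift back toward the number of compound 1 rather than anything beyond the scatter. Compound 3 is expected at about 5000 nM, within 2500 nM to 10000 nM.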

Compound 3, half-maximal inhibitory concentration: 7550 nM
The estimate for compound 3 lay 1.5-fold (0.18 log units) below the measured number, within the range that was stated.
By their numbers in this assay, from the lowest: compounds 1, 2 and 3 (each within the scatter of the next).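

In this assay the aryl group on the carbonyl carbon now includes a six-membered aromatic ring with a hetero atom, and 6-chloropyridin-3-yl gives both a 1.1-fold higher number from compound 2 to compound 3 (0.06 log units; within the scatter) and a 1.9-fold higher number from compound 1 to compound 3 (0.27 log units; within the scatter) as its readings against the two halogen-bearing phenyl groups. The position has therefore taken three aryl groups, one of them with a ring nitrogen and a hydrogen-bond acceptor that 3-fluorophenyl lacks, without any step beyond the scatter, and compounds 1, 2 and 3 cannot be ranked against each other. No measurement at hand speaks to what lies behind these numbers.

Going by these compounds, all three groups at this position are six-membered aromatic rings carrying a single halogen, so it remains open whether an amine or a carboxylic acid on the ring, or a saturated piperidine ring in place of the aryl group, would give a step beyond the scatter. The amide link and the 4-fluorophenyl group on the shared core are also common to all three compounds, which leaves open how much either one contributes to the numbers in this assay.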